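From pentyl to pentyloxy on an aromatic carbon

This account rests on a few compounds, and the source may have more. Where it says the series, first, only, none or still open, it means among the compounds named here.

In a functional assay on brain (Rattus norvegicus, strain Wistar) for inhibition (a lower number here means a stronger inhibitor, a higher number a weaker inhibitor), compound 1 `CCCCc1ccc(-c2c(C)[nH]c(=O)n2C)cc1` gives 10700 nM, compound 2 `CCCc1ccc(-c2c(C)[nH]c(=O)n2C)cc1` gives 21500 nM and compound 3 `CCCCCc1ccc(-c2c(C)[nH]c(=O)n2C)cc1` gives 5900 nM. Compound 3 has the lowest of these numbers, but it is separated clearly only from compound 2, as a 3.6-fold lower number from compound 2 to compound 3 (0.56 log units; beyond the scatter) shows, while a 1.8-fold lower number from compound 1 to compound 3 (0.26 log units; within the scatter) does not separate it from compound 1. The neighbouring step a 2.0-fold higher number from compound 1 to compound 2 (0.30 log units; within the scatter) is likewise small. Compound 4 `CCCCCOc1ccc(-c2c(C)[nH]c(=O)n2C)cc1` carries pentyloxy in place of pentyl on an aromatic carbon. Within the data shown here, no measured compound holds pentyloxy, so these chain steps offer only loose guidance. A small move towards a lower number is expected, probably within the scatter. The expected change is a 1.3-fold lower number from compound 3 to compound 4 (0.12 log units; within the scatter). Compound 4 is estimated at 4500 nM, with an expected range from 1800 nM to 11000 nM.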

Compound 4, half-maximal inhibitory concentration: 4500 nM
Compound 4: the middle estimate sits on the measured number at the digits printed; the range from low to high includes it.
By their numbers in this assay, from the lowest: compounds 4, 3, 1 and 2 (each within the scatter of the next, the first and the last beyond it).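

Pentyloxy brings one oxygen and one hydrogen-bond acceptor to this aromatic carbon, yet in this assay the outcome stays within the scatter, with a 1.3-fold lower number from compound 3 to compound 4 (0.12 log units; within the scatter). Compound 4 also stands clear of the shorter chains, with a 4.8-fold lower number from compound 2 to compound 4 (0.68 log units; beyond the scatter) and a 2.4-fold lower number from compound 1 to compound 4 (0.38 log units; beyond the scatter); the separation from compound 1 is one that compound 3 did not reach. Nothing available explains why the oxygen leaves the number so little changed. Open, from the compounds shown here alone, is whether a longer chain on the oxygen, or an amine in its place, would shift the number beyond the scatter.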